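The source may hold more compounds than are shown below. What is called first, only, known or untested is meant among the compounds shown, and "the series" means these compounds.

Among the measured compounds shown here, compound 1 `CNC(=O)CCCCCc1cccc2cncn12` is the weaker of the two compounds measured so far: in an assay for inhibition of Thromboxane-A synthase (Homo sapiens) (on this read-out lower numbers stand for stronger inhibition and higher numbers for weaker inhibition), compound 1 gives 270 nM, the highest of the two numbers in hand. For the measured compounds named here, compound 2 `O=C(O)/C=C/CCCc1cccc2cncn12` gives 4.8 nM in this assay, and the step of a 56-fold lower number from compound 1 to compound 2 (1.75 log units; beyond the scatter) is the only measured change available for comparison. Compound 3 `C/C(=C\CCCCCc1cccc2cncn12)C(=O)O` has not yet been measured. It departs from compound 1 by 2-carboxyprop-1-en-1-yl in place of methylcarbamoyl on a saturated chain carbon, five bonds along the chain from an aromatic carbon. As in the step to compound 2, a carboxylic acid on an unsaturated chain enters where the methylcarbamoyl group of compound 1 leaves, so the measured step from compound 1 to compound 2 bears directly on what to expect. Compound 3 is therefore expected to show a large move toward a lower number, a 27-fold lower number from compound 1 to compound 3 (1.43 log units; beyond the scatter), though the longer chain makes the size less certain. For compound 3 the estimate in this assay is 10 nM, within a range of 2 nM to 50 nM.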

Compound 3, half-maximal inhibitory concentration: 19 nM
Compound 3: middle estimate off by 1.9-fold (0.28 log units), on the low side; measured number inside the range.
By their numbers in this assay, from the lowest: compound 2; then compound 3; then compound 1.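

In this assay, replacing methylcarbamoyl with 2-carboxyprop-1-en-1-yl on a saturated chain carbon, five bonds along the chain from an aromatic carbon, gives a 14-fold lower number from compound 1 to compound 3 (1.15 log units; beyond the scatter), a large step. The fall in number seen earlier with 2-carboxyethenyl is therefore not confined to that one group or place, since a second unsaturated chain ending in a carboxylic acid also lowers the number from that of compound 1, and no compound shown goes against this. Nothing available explains why either change lowers the number.

On these data alone, because chain length, the added methyl and the double bond all differ together in compound 3, the share of each stays open. As far as these compounds go, it also stays open how a saturated chain ending in a carboxylic acid, or a chain ending in a tetrazole, would compare.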